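The source may hold more compounds than are shown below. What is called first, only, known or untested is meant among the compounds shown, and "the series" means these compounds.

Measured so far:
- Compound 1 `Cn1cc(NC(=O)c2cnc3ccc(N4CCC[C@@H](N)C4)nn23)c(C(F)F)n1`: 10700 nM
- Compound 2 `Cn1cc(NC(=O)c2cnc3ccc(N[C@@H]4CCCNC4)nn23)c(C(F)F)n1`: 700 nM
- Compound 3 `Cn1cc(NC(=O)c2cnc3ccc(N[C@H]4CCCNC4)nn23)c(C(F)F)n1`: 22300 nM

All three values come from a functional assay on OCI-Ly10 cells (Homo sapiens) for cytotoxicity, read by CCK-8 assay, with a stated time of 72 h; on this read-out lower numbers stand for stronger inhibition and higher numbers for weaker inhibition. Compound 3 gives the highest number of the set, 22300 nM, and is the weakest of the three.

The next compound, compound 4 `Cn1cc(NC(=O)c2cnc3ccc(N[C@@H]4CCNC4)nn23)c(C(F)F)n1`, has pyrrolidin-3-yl in place of piperidin-3-yl on a nitrogen on an aromatic ring. Among the compounds with values here, no measured step alters the ring size, so that part of the change remains untested. The stereocentre, however, is drawn in compound 4 in the same sense as in compound 2. The most relevant measurement is therefore a 32-fold higher number from compound 2 to compound 3 (1.50 log units; beyond the scatter), a large step that comes with the fact that compounds 2 and 3 differ only in the configuration as drawn. The large 15-fold lower number from compound 1 to compound 2 (1.18 log units; beyond the scatter) and the modest 2.1-fold higher number from compound 1 to compound 3 (0.32 log units; beyond the scatter) show how far this amine placement and configuration can move the number.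

A large fall in the number is expected, somewhat smaller than the full gap between compound 2 at 700 nM and compound 3, given the untested ring change. The estimate is a 12-fold lower number from compound 3 to compound 4 (1.09 log units; beyond the scatter). For compound 4 the expected value is 1800 nM, with an estimated range from 350 nM to 9000 nM.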

Compound 4, half-maximal inhibitory concentration: 3600 nM
The estimate for compound 4 lay 2.0-fold (0.30 log units) below the measured number; measured number inside the range.
By their numbers in this assay, from the lowest: compound 2; then compound 4; then compound 1; then compound 3.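

Within the data shown here, with the stereocentre drawn in the same sense, the step of a 5.1-fold higher number from compound 2 to compound 4 (0.71 log units; beyond the scatter) gives the first reading of ring size at this position, and it is smaller than the step that rests on configuration alone, a 32-fold higher number from compound 2 to compound 3 (1.50 log units; beyond the scatter): the fact that compounds 2 and 3 differ only in the configuration as drawn. The step of a 6.2-fold lower number from compound 3 to compound 4 (0.79 log units; beyond the scatter) carries the ring change together with the opposite drawn configuration, so it cannot be read as an effect of ring size alone. The step of a 3.0-fold lower number from compound 1 to compound 4 (0.47 log units; beyond the scatter) shows that (pyrrolidin-3-yl)amino still gives a lower number than 3-aminopiperidin-1-yl, though by less than the (piperidin-3-yl)amino of compound 2.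

The compounds shown hold pyrrolidin-3-yl in one drawn sense only, so it remains open whether configuration matters as much on this ring as on piperidin-3-yl. Also open, going by these compounds, is how an azetidin-3-yl ring, or a methyl group on the ring nitrogen, would behave here.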